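Two Sulfonamides at the Assay Limit, a Third Variant

This account rests on a few compounds, and the source may have more. Where it says the series, first, only, none or still open, it means among the compounds named here.

Compound 1 `CCOc1cc(C(Nc2ccc3cnccc3c2)C(=O)NS(=O)(=O)c2ccc(S(C)(=O)=O)cc2)ccc1OC(C)C`: > 5000 nM
Compound 2 `CCOc1cc(C(Nc2ccc3cnccc3c2)C(=O)NS(=O)(=O)c2ccccc2S(=O)(=O)CC)ccc1OC(C)C`: > 5000 nM

In an assay on isolated protein for inhibition of Trypsin (Homo sapiens) (on this read-out lower numbers stand for stronger inhibition and higher numbers for weaker inhibition), compound 1 gives > 5000 nM, which is a limit of the assay and not a number. In this assay compound 2 gives > 5000 nM, again a limit. The step between them is a step that the two limits leave unreadable from compound 1 to compound 2. Both values sit at the limit of > 5000 nM in this assay, at which 2 of the 2 values shown sit, so compound 2 stands at the limit with no readable position within it.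

Compound 3 `CCOc1cc(C(Nc2ccc3cnccc3c2)C(=O)NS(=O)(=O)c2cccc(S(=O)(=O)N(C)C)c2)ccc1OC(C)C` has not yet been measured. It differs from compound 2 in one place: 3-(dimethylsulfamoyl)phenyl in place of 2-(ethylsulfonyl)phenyl on a sulfonyl sulfur. Among the compounds with values here, the only measured step also swaps one sulfonyl-bearing phenyl group for another on the same sulfonyl sulfur, and its size cannot be read; no measured step shows any readable movement in this assay. Compound 3 is therefore expected to give a limit again, estimated around 10000 nM, between 3000 nM and 50000 nM. For compound 3 the expected step is a step that the limit leaves unreadable from compound 2 to compound 3, meaning no movement beyond the scatter.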

Compound 3, inhibition constant: > 5000 nM
Compound 3 was reported as a limit; the forecaster's own chance of this, stated with the estimate: 85%; the middle value does not contradict the limit.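

No step between compound 1, compound 2 and compound 3 can be read, because each result in this assay is a limit and not a number: the limit of > 5000 nM in this assay, at which 3 of the 3 values shown sit.

The compounds shown leave open how strong each one really is, and whether changing the phenyl group on the sulfonyl sulfur makes any difference.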